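Cyclohexyl in Place of Benzyl: Cytotoxicity Outlook

The compounds below may be only part of what the source reports. "The series", "measured", "known", "first", "only" and "open" are said of these compounds alone.

Of the compounds shown here, three have so far been tested in a functional assay on MDA-MB-231 cells (Homo sapiens) for cytotoxicity, read by MTT assay, with a stated time of 48 h; a higher number here means a weaker inhibitor, a lower number a stronger inhibitor. Compound 1 `COc1cc(CN(C(=O)Nc2ccc(C#N)cc2)n2cnnc2)cc(OC)c1OC` gives > 50000 nM in this assay, and this is only a limit of the assay, not a number. Compound 3 `COc1ccc(CN(C(=O)Nc2ccc(C#N)cc2)n2cnnc2)cc1OC` gives > 50000 nM, again only a limit. Compound 2 `O=C(NCc1ccccc1)N(Cc1ccccn1)n1cnnc1` gives > 50000 nM, also a limit. For the measured compounds named here, the one step between measured compounds, hydrogen in place of methoxy on an aromatic carbon, is a step that the two limits leave unreadable from compound 1 to compound 3; its size cannot be read because of the limit of > 50000 nM in this assay, at which 3 of the 3 values shown sit.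

Compound 4 `O=C(NC1CCCCC1)N(Cc1ccccn1)n1cnnc1` has not yet been measured. It differs from compound 2 by cyclohexyl in place of benzyl on an amide-type nitrogen. Going by the values given here, no measured step touches this kind of change, so there is nothing to say in which direction it moves potency. Compound 2 stands at the limit in this assay, and compound 4 is therefore expected to stay near or beyond that limit, with an estimated value of 80000 nM and a range from 30000 nM to 300000 nM. The expected step that the limit leaves unreadable from compound 2 to compound 4 is most likely not readable at all, with the assay again reporting only a limit.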

Compound 4, half-maximal inhibitory concentration: 44100 nM
Beside the measured number, compound 4's estimate is 1.8-fold (0.26 log units) above it; the range from low to high includes it.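

In this assay compound 4 gives 44100 nM, the only actual number among the compounds shown, so this position on the amide-type nitrogen can carry a change that brings a reading inside the range of the assay. Compound 2 gives > 50000 nM, which is only a limit. Cyclohexyl in place of benzyl therefore gives an at least 1.1-fold lower number from compound 2 to compound 4 (0.05 log units; that floor lies within the scatter), so the change can be stated only as a floor, and that floor does not separate the two compounds.

On these data alone, how large the true step is stays open because the other compounds give no number to compare with: the limit of > 50000 nM in this assay, at which 3 of the 4 values shown sit. Also open is whether a shorter chain such as methyl, an amine or a carboxylic acid on this nitrogen would give a lower number than cyclohexyl.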